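A few compounds are considered here, and "the series" means these few. Any claim that something is new, unique, unknown or untested is made for them only; others in the source may bear on it.

In a functional assay on DU-145 cells (Homo sapiens) for cytotoxicity, read by ELISA, with a stated time of 4 days (on this read-out higher numbers stand for weaker inhibition and lower numbers for stronger inhibition), the measured compounds read as follows:
Compound 1 `Clc1ccc(-c2cc(-c3ccco3)cc(-c3ccc(Cl)s3)n2)cc1` gives 14800 nM
Compound 2 `Cc1cccc(-c2cc(-c3ccoc3)cc(-c3ccc(Cl)s3)n2)c1` gives 20300 nM
Compound 3 `Clc1cccc(-c2cc(-c3ccoc3)cc(-c3ccc(Cl)s3)n2)c1` gives 23000 nM

Compound 3, at 23000 nM in this assay, lies within the usual scatter of both other compounds. Compound 4 `Clc1ccc(-c2cc(-c3ccoc3)cc(-c3ccc(Cl)s3)n2)cc1` has the same atoms joined differently: 4-chlorophenyl in place of 3-chlorophenyl on an aromatic carbon. Within the data shown here, no measured step moves the chlorine itself, so the evidence is indirect. Among the measured compounds shown here, the one step between close neighbours, chloro in place of methyl on an aromatic carbon, is a 1.1-fold higher number from compound 2 to compound 3 (0.05 log units; within the scatter) and stays within the scatter. Compound 1, which also carries 4-chlorophenyl, gives 14800 nM and is no further from compound 3 than the scatter allows. Nothing here points to a step beyond the scatter, and none is expected. The estimated step is a 1.2-fold lower number from compound 3 to compound 4 (0.08 log units; within the scatter) and is expected to remain within the scatter. Compound 4 is expected at 19000 nM, with an estimated range from 10000 nM to 36000 nM.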

Compound 4, half-maximal inhibitory concentration: 29500 nM
The estimate for compound 4 lay 1.6-fold (0.19 log units) below the measured number; the measured number falls inside the stated range.
By their numbers in this assay, from the lowest: compounds 1, 2, 3 and 4 (each within the scatter of the next).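

In this assay, 4-chlorophenyl in place of 3-chlorophenyl is a 1.3-fold higher number from compound 3 to compound 4 (0.11 log units; within the scatter), the only step shown that moves the chlorine itself, and 4-chlorophenyl in place of 3-methylphenyl is a 1.5-fold higher number from compound 2 to compound 4 (0.16 log units; within the scatter). The furan attachment can now also be read directly: furan-3-yl in place of furan-2-yl is a 2.0-fold higher number from compound 1 to compound 4 (0.30 log units; within the scatter). Neither the place of the chlorine on the phenyl group nor the furan attachment therefore separates these compounds in this assay, and no supporting measurement offers an explanation for these readings.

On these data alone, all four compounds carry a substituted phenyl group at this position, so the effect of an amine, a carboxylic acid or a longer chain there remains open. As far as these compounds go, whether a group other than a furan at the second position would give a step beyond the scatter also remains open.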